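Swapping nitro for chloro on a shared core

This account rests on a few compounds, and the source may have more. Where it says the series, first, only, none or still open, it means among the compounds named here.

Compound 3 `COC(=O)[C@H](CCSC)NC(=O)c1ccc(NCc2cncn2Cc2cccc([N+](=O)[O-])c2)cc1-c1ccccc1` belongs to a small set built on one shared core. In a functional assay on NIH3T3 cells (Mus musculus) (a lower number here means that less compound is needed, a higher number that more compound is needed for the effect), compound 3 gives > 10 uM, which is a limit, not a number. Compound 2 `COC(=O)[C@H](CCSC)NC(=O)c1ccc(NCc2cncn2Cc2ccc(Cl)cc2)cc1-c1ccccc1` gives > 10 uM in this assay, likewise a limit. Compound 1 `N#Cc1ccc(Cn2cncc2CNc2ccc(C(=O)NCc3ccccc3)c(-c3ccccc3)c2)cc1` gives > 10 uM in this assay, again a limit. Among the compounds with values here, the single step between measured compounds, a step that the two limits leave unreadable from compound 2 to compound 3, cannot be sized because of the limit of > 10 uM in this assay, at which 3 of the 3 values shown sit. Compound 4 `COC(=O)[C@H](CCSC)NC(=O)c1ccc(NCc2cncn2Cc2cccc(Cl)c2)cc1-c1ccccc1` differs from compound 3 by chloro in place of nitro on an aromatic carbon. Within the data shown here, no measured step reaches this exact change. Compound 4 is therefore expected to remain near that same limit in this assay, with a step that the limit leaves unreadable from compound 3 to compound 4 as the estimated step. The estimate for compound 4 is 20 uM, spanning 7 uM to 60 uM.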

Compound 4, concentration for half-maximal effect: > 10 uM
Compound 4: no number, only a limit; the forecaster's own chance of this, stated with the estimate: 85%; the middle value does not contradict the limit.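

Compound 4 gives > 10 uM, which is a limit, so its steps from compound 2 and compound 3 cannot be read: the limit of > 10 uM in this assay, at which 4 of the 4 values shown sit.

How chloro and nitro compare in this assay stays open, as does where any of these compounds would give an actual number.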